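This account rests on a few compounds, and the source may have more. Where it says the series, first, only, none or still open, it means among the compounds named here.

Measured so far in a functional assay on HT-29 cells (Homo sapiens) for cytotoxicity, read by MTT assay, with a stated time of 72 h; on this read-out higher numbers stand for weaker inhibition and lower numbers for stronger inhibition: compound 1 `COc1cc2c(Oc3ccc(NC(=O)c4cn(-c5ccc(Cl)cc5Cl)cn4)cc3F)ccnc2cc1OCCCN1CCN(C)CC1` gives 3050 nM; compound 2 `COc1cc2c(Oc3ccc(NC(=O)c4cn(-c5ccccc5OC(F)(F)F)cn4)cc3F)ccnc2cc1OCCCN1CCCCC1` gives 250 nM; compound 3 `COc1cc2c(Oc3ccc(NC(=O)c4cn(-c5ccc(Cl)cc5)cn4)cc3F)ccnc2cc1OCCCN1CCCCC1` gives 2780 nM.

Going by the values given here, compound 3 holds the second highest of the three numbers; compound 1 lies within the scatter of it, and the one step beyond the scatter is an 11-fold higher number from compound 2 to compound 3 (1.05 log units; beyond the scatter). Compound 4 `COc1cc2c(Oc3ccc(NC(=O)c4cn(-c5ccc(Cl)cc5Cl)cn4)cc3F)ccnc2cc1OCCCN1CCCCC1` differs from compound 3 by chloro in place of hydrogen on an aromatic carbon, ortho to a large group and meta to a chloro group. Among the compounds with values here, no measured step covers this addition directly. Compound 1 carries the same 2,4-dichlorophenyl group and gives 3050 nM, close to compound 3; the step of an 11-fold higher number from compound 2 to compound 3 (1.05 log units; beyond the scatter) shows the aromatic-nitrogen substituent can shift the number strongly, but that comparison swaps a different group. Compound 4 is therefore expected to move little, a 1.4-fold lower number from compound 3 to compound 4 (0.14 log units; within the scatter). The estimate for compound 4 is 2000 nM, range 600 nM to 5000 nM.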

Compound 4, half-maximal inhibitory concentration: 4300 nM
Estimate against measurement, compound 4: 2.2-fold (0.33 log units) below; low and high end bracket the measured number.
By their numbers in this assay, from the lowest: compound 2; then compounds 3, 1 and 4 (each within the scatter of the next).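

In this assay, chloro in place of hydrogen on the aromatic carbon of the 4-chlorophenyl group gives no change beyond the scatter (a 1.5-fold higher number from compound 3 to compound 4 (0.19 log units; within the scatter)). The new compound also shows that piperidin-1-yl in place of 4-methylpiperazin-1-yl at the chain end stays within the scatter (a 1.4-fold higher number from compound 1 to compound 4 (0.15 log units; within the scatter)). The large gap remains with the group on the aromatic nitrogen: 2,4-dichlorophenyl in place of 2-(trifluoromethoxy)phenyl gives a 17-fold higher number from compound 2 to compound 4 (1.24 log units; beyond the scatter).

From the compounds shown here alone, whether 2-chlorophenyl or 2-(trifluoromethyl)phenyl on that nitrogen would come close to compound 2 stays open. No evidence at hand accounts for any of these steps.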